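The source may report more compounds than this note shows. Statements on the series, on what has been measured and on what is new or still open speak of the compounds shown alone.

Compound 1, `COc1ccc(/C=C/C(=O)Nc2cc(C(=O)c3cc(OC)c(OC)c(OC)c3)ccc2OC)cc1`, gives 12800 nM in a functional assay on DU-145 cells (Homo sapiens) for cytotoxicity, read by MTT assay, with a stated time of 72 h; a higher number here means a weaker inhibitor, a lower number a stronger inhibitor.
Compound 2, `COc1cccc(/C=C/C(=O)Nc2cc(C(=O)c3cc(OC)c(OC)c(OC)c3)ccc2OC)c1`, gives 6200 nM in this assay.
Compound 3, `COc1ccc(C(=O)c2cc(OC)c(OC)c(OC)c2)cc1NC(=O)/C=C/c1ccc(F)cc1`, gives 3900 nM in this assay.

All three share one core and differ only in the aromatic ring that carries the double-bonded chain. Compound 3 has the lowest number of the three: the step of a 3.3-fold lower number from compound 1 to compound 3 (0.52 log units; beyond the scatter) lies beyond the scatter, while the gap a 1.6-fold lower number from compound 2 to compound 3 (0.20 log units; within the scatter) lies within it, so compound 3 can be set apart from compound 1 but not from compound 2.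

Compound 4, `COc1ccc(C(=O)c2cc(OC)c(OC)c(OC)c2)cc1NC(=O)/C=C/c1ccc(N)cc1`, is not yet measured. It differs from compound 3 in one place: amino in place of fluoro on an aromatic carbon. Within the data shown here, no measured step swaps fluoro for amino, so the known steps bear on it only indirectly. The step of a 3.3-fold lower number from compound 1 to compound 3 (0.52 log units; beyond the scatter) exchanged the group on that same aromatic carbon, methoxy for fluoro, and the step of a 1.6-fold lower number from compound 2 to compound 3 (0.20 log units; within the scatter) exchanged the whole ring; one was modest, the other within the scatter. Changes on this ring have so far moved the numbers only a little, and nothing here says whether amino behaves like methoxy or like fluoro. The expectation is therefore a step of a 1.2-fold higher number from compound 3 to compound 4 (0.06 log units; within the scatter), not clearly beyond the scatter in either direction, with a wide range. Compound 4 is expected to give 4500 nM, between 1500 nM and 13000 nM.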

Compound 4, half-maximal inhibitory concentration: 13500 nM
For compound 4 the middle estimate is 3.0-fold (0.48 log units) below the measured one; the measured number lies above the stated range.
By their numbers in this assay, from the lowest: compounds 3 and 2 (each within the scatter of the next); then compounds 1 and 4 (each within the scatter of the next).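

Exchanging a single fluoro for amino on this aromatic carbon, para to a large group, gives a step of a 3.5-fold higher number from compound 3 to compound 4 (0.54 log units; beyond the scatter), so this position does respond to the group it carries, although the earlier ring changes left it unclear how far. Amino and methoxy cannot be told apart here, with a step of a 1.1-fold higher number from compound 1 to compound 4 (0.02 log units; within the scatter), while the step of a 2.2-fold higher number from compound 2 to compound 4 (0.34 log units; beyond the scatter) separates the 4-aminophenyl compound from the 3-methoxyphenyl one, so among the three groups on this carbon only fluoro stands apart, with the lower number. No measurement shown here offers a reason for this difference.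

As far as these compounds go, whether the lower number belongs to fluoro alone stays open: a chloro or a hydroxyl group on this carbon, or a dimethylamino group in place of amino, would test that. Also open, from the compounds shown here alone, is whether an amino group on the ring carbon holding the methoxy in compound 2 would give a number like that of compound 2 or like that of compound 4.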